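A few compounds are considered here, and "the series" means these few. Any claim that something is new, unique, unknown or untested is made for them only; others in the source may bear on it.

Measured in an ADME assay on CEM-SS cells (Homo sapiens) for cytotoxicity, read by XTT assay; on this read-out lower numbers stand for higher toxicity in this test and higher numbers for lower toxicity in this test:
Compound 1 `O=C(NO)c1cc2ccn(Cc3ccc(F)cc3F)c2cn1`: > 320000 nM
Compound 2 `O=C(NO)c1cc2ccn(Cc3ccc(F)cc3)c2cn1`: 159000 nM

Going by the values given here, compound 2 gives 159000 nM, the only actual number in this assay so far. Compound 1 reads > 320000 nM, which is a limit of the assay and not a number.

Compound 3 `N#Cc1cc(F)ccc1Cn1ccc2cc(C(=O)NO)ncc21` differs from compound 2 by cyano in place of hydrogen on an aromatic carbon. In words, this is cyano in place of hydrogen on an aromatic carbon. Among the compounds with values here, the only measured step that bears on this change is an at least 2.0-fold lower number from compound 1 to compound 2 (0.30 log units; that floor lies within the scatter), with hydrogen in place of fluoro on an aromatic carbon. Within the data shown here, no measured step involves cyano. On that single step, no change beyond the scatter is expected in this assay, with at most a slight lean towards a higher number. The estimated step is a 1.1-fold higher number from compound 2 to compound 3 (0.05 log units; within the scatter). For compound 3 the expected value is 180000 nM, with an estimated range of 70000 nM to 320000 nM.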

Compound 3, half-maximal cytotoxic concentration: > 10000 nM
Compound 3: only a limit was reported (the forecaster's own chance of this, stated with the estimate: 40%); the middle value does not contradict the limit.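

In this assay compound 3 gives > 10000 nM, which is a limit of the assay and not a number. Going by these compounds alone, no step from compound 1 or compound 2 to compound 3 can be read. The compounds shown leave open whether cyano in place of hydrogen on an aromatic carbon changes the half-maximal cytotoxic concentration at all.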